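The source may report more compounds than this note shows. Statements on the series, on what has been measured and on what is new or still open speak of the compounds shown alone.

Compound 3, `Nc1nc(N)nc(-c2cccc(Br)c2)n1`, stands highest of the three measured numbers in a functional assay on the whole organism with Rattus norvegicus as the target, at a dose of 20 mg/kg by the intraperitoneal route; a lower number here means less inhibition, a higher number more inhibition at the dose given (going by the name of the read-out): compound 3 gives 96%. Compound 2, `Nc1nc(N)nc(-c2cccc(F)c2)n1`, gives 70% and is the nearest, while compound 1, `COc1ccc(Br)cc1-c1nc(N)nc(N)n1`, gives 49% and lies furthest. Both measured steps run toward compound 3: a number 47 percentage points higher from compound 1 to compound 3 (beyond the scatter) came with hydrogen in place of methoxy on an aromatic carbon, and a number 26 percentage points higher from compound 2 to compound 3 (beyond the scatter) came with bromo in place of fluoro on an aromatic carbon.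

Compound 4, `Nc1nc(N)nc(-c2cc(Br)ccc2F)n1`, differs from compound 3 by fluoro in place of hydrogen on an aromatic carbon. Going by the values given here, no measured step places a fluoro at this position, so the bearing of the two known steps is indirect: the only measured change at a carbon ortho to the core, that from compound 1 to compound 3, removed a methoxy and gave a large rise, and the change from compound 2 to compound 3 concerned a different carbon. With compound 3 already near the top of the percentage scale, the step of a number 11 percentage points lower from compound 3 to compound 4 (beyond the scatter) is expected to be small, downward if anything. Compound 4 is therefore estimated at 85%, within 60% to 100%.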

Compound 4, a percentage reported as inhibition, in the whole organism at one dose (the size of the read-out at that dose, not a potency): 100%
Beside the measured number, compound 4's estimate is 15 percentage points below it; the measured number falls inside the stated range.
By their numbers in this assay, from the lowest: compound 1; then compound 2; then compounds 3 and 4 (each within the scatter of the next).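

In this assay the new fluoro, on an aromatic carbon ortho to a group of 8 heavy atoms and para to a bromo group, gave a number 4 percentage points higher from compound 3 to compound 4 (within the scatter) and so left the read-out level with hydrogen at this carbon. With a number 51 percentage points higher from compound 1 to compound 4 (beyond the scatter) as the second step, methoxy is the only one of the three groups shown at this carbon that goes with a clearly lower number. Nothing in hand explains either step.

Compound 4 gives 100% and so stands at the top of the percentage scale, which means that this single dose cannot separate it from compound 3 any further. From the compounds shown here alone, it stays open whether chloro, hydroxy or an amine at this carbon would stay level with fluoro and hydrogen or fall toward methoxy.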